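The compounds below may be only part of what the source reports. "The series", "measured", "known", "first", "only" and "open" are said of these compounds alone.

Compound 2 `CCCCCc1nn(C[C@H]2CCCN2C)c(=O)c2ccccc12` is one of two compounds whose binding has been measured in an assay for binding affinity to Alpha-1A adrenergic receptor (Homo sapiens); a higher number here means a weaker inhibitor, a lower number a stronger inhibitor. In this assay, within the data shown here, compound 2 gives 501 nM, the higher of the two numbers, and its only neighbour is compound 1 `CN1CCC[C@@H]1Cn1nc(Cc2cccc(F)c2)c2ccccc2c1=O`, which in this assay gives 50.1 nM. Among the measured compounds shown here, the one step between these two, a 10-fold higher number from compound 1 to compound 2 (1.00 log units; beyond the scatter), replaces an aromatic group with a chain at the saturated chain carbon bound to an aromatic carbon. Compound 3 `COc1ccc(Cc2nn(C[C@H]3CCCN3C)c(=O)c3ccccc23)cc1` reverses that kind of change: 4-methoxyphenyl in place of butyl on a saturated chain carbon bound to an aromatic carbon. For the measured compounds named here, the step from compound 1 to compound 2 is the only measured step that bears on this, and it points the other way, so it is expected that restoring an aromatic ring at this position brings the number back down by roughly the same amount, an 8.4-fold lower number from compound 2 to compound 3 (0.92 log units; beyond the scatter), with some uncertainty because the ring in compound 3 carries a methoxy group in place of the fluorine of compound 1. Compound 3 is therefore estimated to give 60 nM in this assay, most likely between 20 nM and 200 nM.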

Compound 3, inhibition constant: 126 nM
The estimate for compound 3 lay 2.1-fold (0.32 log units) below the measured number, within the range that was stated.
By their numbers in this assay, from the lowest: compound 1; then compound 3; then compound 2.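

In this assay, a second aromatic ring at the saturated chain carbon bound to an aromatic carbon also gives a lower number than butyl, with a 4.0-fold lower number from compound 2 to compound 3 (0.60 log units; beyond the scatter) set against the earlier 10-fold higher number from compound 1 to compound 2 (1.00 log units; beyond the scatter) in the opposite direction. The ring itself therefore does not fix the number at this position: the two rings differ, with a 2.5-fold higher number from compound 1 to compound 3 (0.40 log units; beyond the scatter) on exchanging 3-fluorophenyl for 4-methoxyphenyl, so 4-methoxyphenyl recovers only part of the distance from butyl to 3-fluorophenyl. No measurement is available here that would account for these differences.

The exchange from 3-fluorophenyl to 4-methoxyphenyl alters both the substituent and the printed ring position at once, so the compounds shown leave open which of the two matters, a question that 4-fluorophenyl or 3-methoxyphenyl at this place would help to separate. They also leave open where a phenyl ring with no substituent would fall relative to these two rings, and how a chain longer than butyl or one ending in an amine would compare.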